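Anilino-substituted series: cytotoxicity notes on compounds 1 and 3

This account rests on a few compounds, and the source may have more. Where it says the series, first, only, none or still open, it means among the compounds named here.

Within the data shown here, compound 1 `COc1ccc(Nc2ncnc3c(=N)n(NC(=O)c4ccncc4)cnc23)cc1` is the one member of the series with a number in hand. In an ADME assay on Vero cells (Chlorocebus sabaeus) for cytotoxicity (a lower number here means that less compound is needed, a higher number that more compound is needed for the effect), compound 1 gives 1.15 ug/mL. Compound 2 `COc1ccc(Nc2ncnc3c(=N)n(NC(=O)c4ccco4)cnc23)cc1` carries a different acyl group on the same core and has no number in this assay; its entry reads "not determined" (no result reported), so it offers no comparison to compound 1.

Compound 3 `N=c1c2ncnc(Nc3ccc(F)cc3)c2ncn1NC(=O)c1ccncc1` is the next entry for this assay. The change from compound 1 is fluoro in place of methoxy on an aromatic carbon, the rest of the shared core left untouched. Among the measured compounds shown here, no pair of measured compounds shows what this change does, so the step from compound 1 to compound 3 in this assay can only be expected, not read off from a neighbour.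

The expected step of a 1.3-fold higher number from compound 1 to compound 3 (0.12 log units; within the scatter) is taken to stay within the usual scatter of repeated measurements, with no direction claimed beyond it. Compound 3 is therefore estimated at 1.5 ug/mL in this assay, with a range from 0.5 ug/mL to 5 ug/mL; a limit rather than a number remains a possibility.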

Compound 3, half-maximal effective concentration: 1.53 ug/mL
Beside the measured number, compound 3's estimate is 1.0-fold (0.01 log units) below it; the measured number falls inside the stated range.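

Among these compounds, compound 1 and compound 3 form the first measured pair at this position, so the effect of fluoro in place of methoxy on an aromatic carbon can now be read directly: in this assay the step is a 1.3-fold higher number from compound 1 to compound 3 (0.12 log units; within the scatter). In this one pair, 4-methoxyphenyl and 4-fluorophenyl are not separated by this read-out, even though the exchange removes the hydrogen-bond acceptor counted for methoxy; the result therefore shows no sensitivity to this particular change, on the acyl group shared by compound 1 and compound 3. No measurement on hand bears on why the two compounds read alike.

On these data alone, whether an amine, a carboxylic acid or a longer chain such as butoxy on the same aromatic carbon would give a step beyond the scatter remains open. Also open, as far as these compounds go, is whether fluoro in place of methoxy would read the same way with a different acyl group on the shared core, since one pair cannot establish a trend for the series.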